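Pyrrolidine in Place of a Methoxyanilino Group on the Core

This account rests on a few compounds, and the source may have more. Where it says the series, first, only, none or still open, it means among the compounds named here.

Among the compounds with values here, compound 1 `COc1cccc(NC2=CC(=O)c3c(nc4n3[C@H]3OC[C@@H](O)[C@H]3OC4)C2=O)c1` is the only compound here with a numeric result: in a functional assay on MCF7 cells (Homo sapiens) for inhibition, read by sulforhodamine B assay (a higher number here means a weaker inhibitor, a lower number a stronger inhibitor), compound 1 gives 3830 nM. The other value shown belongs to compound 2 `O=C1C=C(NCc2ccccc2)C(=O)c2c1nc1n2[C@H]2OC[C@@H](O)[C@H]2OC1` and is a limit of the assay rather than a number: compound 2 gives > 8000 nM in this assay. That reading sits at the limit of > 8000 nM in this assay, at which 1 of the 2 values shown sits. Compound 3 `O=C1C(N2CCCC2)=CC(=O)c2c1nc1n2[C@H]2OC[C@@H](O)[C@H]2OC1` has not yet been measured. It differs from compound 1 in one place: pyrrolidin-1-yl in place of (3-methoxyphenyl)amino on a double-bonded ring carbon. Within the data shown here, no step between two measured compounds is available, so the size of this move cannot be read from a neighbouring pair. The expectation is a loss of potency somewhat beyond the usual scatter, expressed as the step of a 1.8-fold higher number from compound 1 to compound 3 (0.26 log units; within the scatter). Compound 3 is therefore estimated at 7000 nM in this assay, with a range from 2500 nM to 20000 nM.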

Compound 3, half-maximal inhibitory concentration: > 16000 nM
Compound 3: no number, only a limit; the forecaster's own chance of this, stated with the estimate: 40%; middle value at least 2.2-fold (0.35 log units) from the limit.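

In this assay, within the data shown here, the change at this position appears as an at least 4.1-fold higher number from compound 1 to compound 3 (0.62 log units; beyond the scatter), the first reading of what leaving (3-methoxyphenyl)amino for pyrrolidin-1-yl on this double-bonded ring carbon does to the shared core. The loss lies beyond the usual scatter, although the move takes out the aromatic ring and the hydrogen-bond donor together, so the two cannot be told apart here. Compound 3 gives a limit rather than a number, which means the step has a lower bound but no known upper end: the limit of > 16000 nM in this assay, at which 1 of the 3 values shown sits.

The compounds shown leave open whether the aromatic ring or the amine hydrogen carries the difference. As far as these compounds go, a plain phenylamino group without the methoxy, or a dimethylamino group, could separate these, and how far potency falls for compound 3 also remains unknown.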